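A few compounds are considered here, and "the series" means these few. Any claim that something is new, unique, unknown or untested is made for them only; others in the source may bear on it.

Measured compounds:
compound 1, `O=C(Nc1cccnc1)c1cncc(Br)c1`, with 29% in an assay on V79 cells for inhibition of cytochrome P450 11B2, mitochondrial (Homo sapiens), tested at 500 nM; on this read-out lower numbers stand for less inhibition and higher numbers for more inhibition at the one concentration tested (going by the name of the read-out)
compound 2, `O=C(Nc1cccnc1)c1ccccc1`, with 30% in this assay

On these two numbers compound 2 stands highest, yet its nearest neighbour, compound 1, lies within the usual scatter of it, so the two values show no difference that can be trusted, and the inhibition in this assay can only be called level between the two. Compound 3, `O=C(Nc1cccnc1)c1ccc(C(F)(F)F)cc1`, is not yet measured; it differs from compound 2 by trifluoromethyl in place of hydrogen on an aromatic carbon. For the measured compounds named here, no step between two measured compounds exists here, so nothing in the data shows how this kind of change acts in this assay. The step from compound 2 to compound 3 is expected to be a number 6 percentage points higher from compound 2 to compound 3 (within the scatter), a modest rise that may not reach beyond the scatter. Compound 3 is therefore estimated at 36%, with a range from 15% to 57%.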

Compound 3, a percentage reported as inhibition, at one concentration (the size of the read-out at that concentration, not a potency): 1%
For compound 3 the middle estimate is 35 percentage points above the measured one; the whole stated range lies above it.
By their numbers in this assay, from the lowest: compound 3; then compounds 1 and 2 (each within the scatter of the next).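

Trifluoromethyl in place of hydrogen on an aromatic carbon, para to a group of 9 heavy atoms, gives the first step in this series that can be read in this assay: a number 29 percentage points lower from compound 2 to compound 3 (beyond the scatter). This position is therefore not indifferent to what it carries: with hydrogen there, compound 2 gives 30%, whereas with trifluoromethyl there, compound 3 gives 1%. Nothing at hand accounts for this loss of inhibition.

As far as these compounds go, whether the loss belongs to trifluoromethyl alone or would follow from other groups at this position stays open, and a single fluorine, a methyl group, a methoxy group or an amine in the same place could separate those readings. From the compounds shown here alone, it also remains open whether trifluoromethyl on other carbons of this ring would give a similar result.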